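The compounds below may be only part of what the source reports. "The series", "measured", "known", "first", "only" and "open" are said of these compounds alone.

In an ADME assay on microsomes from liver (Rattus norvegicus) for metabolic stability, read by LC-MS, in the presence of a further agent that is not named here (a higher number here means faster removal of the compound, a lower number slower removal), compound 1 `Cc1ncc(C)n2nc(-c3ccn4cc(-c5ccc(Br)cc5)nc4n3)nc12` gives 15 mL.min-1.g-1 as its reading. Compound 2 `Cc1ncc(C)n2nc(-c3ccc4nc(-c5ccccn5)[nH]c4c3)nc12` gives 11.1 mL.min-1.g-1 in this assay, a number within the usual scatter of that of compound 1, so the two values cannot be told apart. Compound 3 `Cc1nc(-c2ccc3nc(-c4ccccc4)[nH]c3c2)nc2ccccc12` yields no number in this assay but only the limit > 450 mL.min-1.g-1.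

Compound 4 `Cc1ncc(C)n2nc(-c3ccn4cc(-c5ccc(F)cc5)nc4n3)nc12` keeps the core of compound 1 and differs from it in one place (fluoro in place of bromo on an aromatic carbon). The change lies on a six-membered aromatic ring of carbon only, para to a large group, so that 4-bromophenyl becomes 4-fluorophenyl.

Within the data shown here, no pair of measured compounds shows this exchange, so no step beyond the scatter is expected in this assay, and the expectation rests on compound 1 at 15 mL.min-1.g-1 as its starting point. The estimated step of a 1.3-fold lower number from compound 1 to compound 4 (0.10 log units; within the scatter) is expected to stay within the scatter. For compound 4 the expected value is 12 mL.min-1.g-1, with an estimated range from 5 mL.min-1.g-1 to 30 mL.min-1.g-1.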

Compound 4, intrinsic clearance in microsomes: 3.1 mL.min-1.g-1
Beside the measured number, compound 4's estimate is 3.9-fold (0.59 log units) above it; measured number below the stated range.
By their numbers in this assay, from the lowest: compound 4; then compounds 2 and 1 (each within the scatter of the next). At a limit, above all of these: compound 3.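

In this assay, fluoro in place of bromo on the six-membered aromatic ring of carbon only, para to a large group, gives a 4.8-fold lower number from compound 1 to compound 4 (0.68 log units; beyond the scatter). This position is therefore not indifferent to what it carries, even though each group counts a single heavy atom and the rest of compound 1 stays unchanged. Among these compounds, the earlier compounds offered no pair differing in one place, so this is the first single change that can be read, and nothing measured here bears on why the number moves.

The compounds shown leave open how the number responds to other groups at this place, such as chloro, methoxy or an amine, or to plain hydrogen there. They also leave open whether the same exchange would act alike on a different core.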